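From 4-chlorophenyl to 2-chlorophenyl on an amide-type nitrogen

The source may report more compounds than this note shows. Statements on the series, on what has been measured and on what is new or still open speak of the compounds shown alone.

Values measured in a functional assay on HCT-116 cells (Homo sapiens) for inhibition, read by MTT assay, with a stated time of 2 days (a higher number here means a weaker inhibitor of growth, a lower number a stronger inhibitor of growth), for three compounds
Compound 1 `Nc1ccccc1NC(=O)CCCNCC(=O)Nc1cccc(Cl)c1` gives 75000 nM
Compound 2 `Nc1ccccc1NC(=O)CCCNCC(=O)Nc1ccc(Cl)cc1` gives 45000 nM
Compound 3 `Nc1ccccc1NC(=O)c1ccc(NCC(=O)Nc2cccc([N+](=O)[O-])c2)cc1` gives 9000 nM

Compound 2 sits level with compound 1 within the scatter, and the numbers of both lie clearly above that of compound 3, beyond the scatter. The next compound, compound 4 `Nc1ccccc1NC(=O)CCCNCC(=O)Nc1ccccc1Cl`, has not been measured. It carries 2-chlorophenyl in place of 4-chlorophenyl on an amide-type nitrogen and is otherwise the same as compound 2. The closest measured change put 4-chlorophenyl in place of 3-chlorophenyl on that same nitrogen (a 1.7-fold lower number from compound 1 to compound 2 (0.22 log units; within the scatter)) and stayed within the scatter. Going by the values given here, no measured compound carries 2-chlorophenyl yet. With that single step as the guide, no change beyond the scatter is expected in this assay and no direction can be favoured. The expected result is a 1.1-fold higher number from compound 2 to compound 4 (0.05 log units; within the scatter) in this estimate. For compound 4 the expected value is 50000 nM with 25000 nM to 100000 nM as the estimated range.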

Compound 4, concentration for total growth inhibition: > 100000 nM
Compound 4 was reported as a limit; the forecaster's own chance of this, stated with the estimate: 10%; middle value at least 2.0-fold (0.30 log units) away from the limit.
By their numbers in this assay, from the lowest: compound 3; then compounds 2 and 1 (each within the scatter of the next). At a limit, above all of these: compound 4.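

Compound 4 is reported only as a limit, not as an exact number: the limit of > 100000 nM in this assay, at which 1 of the 4 values shown sits. Even so, 2-chlorophenyl in place of 4-chlorophenyl on the amide-type nitrogen gives an at least 2.2-fold higher number from compound 2 to compound 4 (0.34 log units; beyond the scatter), the first step at this position to pass the scatter and so the first sign that the place of the chlorine on this ring can matter for growth inhibition. The comparison with the 3-chlorophenyl compound is less firm, at an at least 1.3-fold higher number from compound 1 to compound 4 (0.12 log units; that floor lies within the scatter), so this floor alone does not separate compound 4 from compound 1.

Going by these compounds, the full size of both steps stays open. Also open, on these data alone, is whether a methoxy group or an amine in place of the chlorine of 2-chlorophenyl would weaken growth inhibition in the same way.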